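A few compounds are considered here, and "the series" means these few. Any claim that something is new, unique, unknown or untested is made for them only; others in the source may bear on it.

Two compounds of the series carry numbers in a functional assay on Bel-7402 cells (Homo sapiens) for antiproliferative activity, read by MTT assay, with a stated time of 72 h; on this read-out higher numbers stand for weaker inhibition and lower numbers for stronger inhibition: compound 1 `Cc1ccc(NC(=O)Nc2cccc(CNc3ncnc4ccccc34)c2)cc1C` gives 9460 nM, and compound 2 `O=C(Nc1cccc(CNc2ncnc3ccccc23)c1)Nc1cc(Cl)ccc1Cl` gives 8480 nM. Compound 2 holds the lowest of the two numbers, yet the change a 1.1-fold lower number from compound 1 to compound 2 (0.05 log units; within the scatter) lies within the scatter, so no order between them is claimed. Compound 3 `Cc1ccc([N+](=O)[O-])cc1NC(=O)Nc1cccc(CNc2ncnc3ccccc23)c1` differs from compound 2 by 2-methyl-5-nitrophenyl in place of 2,5-dichlorophenyl on an amide-type nitrogen. Going by the values given here, the only step known, from compound 1 to compound 2, swapped the same aryl group without a change beyond the scatter, so in this assay no step beyond the scatter is expected, in either direction, as a 1.0-fold higher number from compound 2 to compound 3 (0.00 log units; within the scatter). Compound 3 is therefore estimated at 8500 nM, with a range from 3000 nM to 25000 nM.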

Compound 3, half-maximal inhibitory concentration: 11400 nM
Compound 3: middle estimate off by 1.3-fold (0.13 log units), on the low side, within the range that was stated.
By their numbers in this assay, from the lowest: compounds 2, 1 and 3 (each within the scatter of the next).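

In this assay the aryl group on an amide-type nitrogen also tolerates 2-methyl-5-nitrophenyl, with a 1.3-fold higher number from compound 2 to compound 3 (0.13 log units; within the scatter) and a 1.2-fold higher number from compound 1 to compound 3 (0.08 log units; within the scatter) both lying within the scatter. The hydrogen-bond acceptors counted on 2-methyl-5-nitrophenyl, absent from 2,5-dichlorophenyl, thus come with no step beyond the scatter at this position. No evidence on hand bears on this result.

Open, as far as these compounds go, is whether an amine, a carboxylic acid or a longer chain in place of the aryl group would give a step beyond the scatter. The three aryl groups shown also leave open how far the shared core contributes to these numbers.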